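The source may report more compounds than this note shows. Statements on the series, on what has been measured and on what is new or still open speak of the compounds shown alone.

All four compounds share one core and differ only in the group on the amine nitrogen of the six-membered non-aromatic ring. In a functional assay on CHO-K1 cells for agonist activity at Glucose-dependent insulinotropic receptor (Homo sapiens), read by a luciferase reporter, with a stated time of 5 h (on this read-out lower numbers stand for an effect already at smaller amounts and higher numbers for an effect only at larger amounts of compound), compound 1 `CCCCOC(=O)N1CCC(Oc2ncnc3c2CCN3c2ccc(S(C)(=O)=O)cc2F)CC1` gives 50.1 nM. Exchanging the ethyl on the chain for fluoro gives compound 2 `CS(=O)(=O)c1ccc(N2CCc3c(OC4CCN(C(=O)OCCF)CC4)ncnc32)c(F)c1`, which gives 501 nM, and exchanging it for methoxy gives compound 3 `COCCOC(=O)N1CCC(Oc2ncnc3c2CCN3c2ccc(S(C)(=O)=O)cc2F)CC1`, which gives 316 nM. The steps were a 10-fold higher number from compound 1 to compound 2 (1.00 log units; beyond the scatter) and a 6.3-fold higher number from compound 1 to compound 3 (0.80 log units; beyond the scatter), while between the two substituted chains the step was a 1.6-fold lower number from compound 2 to compound 3 (0.20 log units; within the scatter). Compound 3 therefore stands second highest of the three numbers, close to compound 2 and well apart from compound 1.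

Compound 4 `CCS(=O)(=O)N1CCC(Oc2ncnc3c2CCN3c2ccc(S(C)(=O)=O)cc2F)CC1` carries a different kind of group on that nitrogen: ethylsulfonyl in place of (2-methoxyethoxy)carbonyl on an amine nitrogen in a ring. For the measured compounds named here, none of the measured steps exchanges the whole carbonyl-bearing chain for ethylsulfonyl; they only alter the end of that chain, and those alterations shifted the numbers by modest amounts. Going by the values given here, no measured step bears directly on this change, so the expectation rests on the spread already seen. Compound 4 is expected to land near compound 3, with an estimated step of a 1.3-fold higher number from compound 3 to compound 4 (0.10 log units; within the scatter). The estimate for compound 4 is 400 nM, expected to fall between 100 nM and 1600 nM.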

Compound 4, half-maximal effective concentration: 1580 nM
Compound 4: the middle estimate sits 4.0-fold (0.60 log units) below what was measured, and the stated range covers the measured number.
By their numbers in this assay, from the lowest: compound 1; then compounds 3 and 2 (each within the scatter of the next); then compound 4.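

The earlier compounds shown here altered only the end of the carbonyl-bearing chain, whereas compound 4 shows that exchanging the whole group on this amine nitrogen in a ring for ethylsulfonyl raises the number further in this assay, with a 5.0-fold higher number from compound 3 to compound 4 (0.70 log units; beyond the scatter) and a 3.2-fold higher number from compound 2 to compound 4 (0.50 log units; beyond the scatter), so ethylsulfonyl matches neither of the two substituted chains. Measured against butoxycarbonyl, the change is a 32-fold higher number from compound 1 to compound 4 (1.50 log units; beyond the scatter), the only step among these compounds printed as large, which places compound 1 and compound 4 at the two ends of the series, each with its steps to all others beyond the scatter. Nothing available here accounts for the size of these steps.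

Compound 4 differs from the others in both the linking group and the length of the chain, so the compounds shown cannot separate the part played by the sulfonyl from that of the short ethyl end, and a butylsulfonyl group, which would carry a longer chain on the same sulfonyl, would address this directly. As far as these compounds go, how a simple amide such as butanoyl on this nitrogen would read in this assay also remains open.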